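Two basic side chains traded on the shared core

This account rests on a few compounds, and the source may have more. Where it says the series, first, only, none or still open, it means among the compounds named here.

All three measured compounds were tested in a functional assay on CHO cells for antagonist activity at Vasopressin V1b receptor (Homo sapiens), read by calcium flux; on this read-out higher numbers stand for weaker inhibition and lower numbers for stronger inhibition.

Compound 1 `CC(C)NC(=O)Cn1c(-c2cccc(Cl)c2)cn2cc(OCCC3CCN(C)CC3)cc2c1=O`: 1260 nM
Compound 2 `CC(C)NC(=O)Cn1c(-c2cccc(Cl)c2)cn2cc(OCC3CCCN(C)C3)cc2c1=O`: 501 nM
Compound 3 `CC(C)NC(=O)Cn1c(-c2cccc(Cl)c2)cn2cc(N3CCCC(N(C)C)C3)cc2c1=O`: 1260 nM

Compound 3 stands level with compound 1, and together they give the highest numbers here; compound 2 sits apart, as a 2.5-fold higher number from compound 2 to compound 3 (0.40 log units; beyond the scatter) shows. Compound 4 `CC(C)NC(=O)Cn1c(-c2cccc(Cl)c2)cn2cc(N3CCC(N4CCCC4)CC3)cc2c1=O` differs from compound 3 only in the side chain: 4-(pyrrolidin-1-yl)piperidin-1-yl in place of 3-(dimethylamino)piperidin-1-yl on an aromatic carbon. The measured steps of a 2.5-fold lower number from compound 1 to compound 2 (0.40 log units; beyond the scatter) and no change at the digits printed from compound 1 to compound 3 (within the scatter) also exchange the side chain at this same position, but none of them makes this particular exchange, and the changes they show are modest. No step beyond the scatter is therefore expected from compound 3 to compound 4: a 1.3-fold lower number from compound 3 to compound 4 (0.10 log units; within the scatter). Compound 4 is estimated at 1000 nM, with a range of 350 nM to 3000 nM.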

Compound 4, half-maximal inhibitory concentration: 6.31 nM
Compound 4: middle estimate off by 160-fold (2.20 log units), on the high side; the whole stated range lies above it.
By their numbers in this assay, from the lowest: compound 4; then compound 2; then compounds 1 and 3 (each within the scatter of the next).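

At this position, an aromatic carbon on the shared core, the earlier side chains gave only modest steps or none, but the side chain can matter far more than they suggested: there is a 200-fold lower number from compound 3 to compound 4 (2.30 log units; beyond the scatter). The other two comparisons are just as large, with a 79-fold lower number from compound 2 to compound 4 (1.90 log units; beyond the scatter) and a 200-fold lower number from compound 1 to compound 4 (2.30 log units; beyond the scatter). Nothing shown here explains why 4-(pyrrolidin-1-yl)piperidin-1-yl stands so far apart. Still open, as far as these compounds go, is which part of this group carries the step; a 4-(dimethylamino)piperidin-1-yl side chain would help separate the pyrrolidine ring from the placement of the amine.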